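This account rests on a few compounds, and the source may have more. Where it says the series, first, only, none or still open, it means among the compounds named here.

Compound 1 `COc1ccc(Cc2nnc(NC(=O)/C(C#N)=C/c3ccccc3OS(=O)(=O)c3ccc(F)cc3)s2)cc1` in an ADME assay on HEK-293T cells (Homo sapiens) for inhibition, read by CCK-8 assay, with a stated time of 48 h, tested at 20 uM (on this read-out lower numbers stand for less inhibition of growth and higher numbers for more inhibition of growth at the one concentration tested), gives 6%
Compound 2 `N#C/C(=C\c1ccccc1OS(=O)(=O)c1ccc([N+](=O)[O-])cc1)C(=O)Nc1nnc(Cc2cccc(F)c2)s1` in this assay gives "not toxic" (no number reported)

Within the data shown here, compound 2 has no single number on this growth inhibition read-out, so its standing is verbal only and no step from it can be computed. Compound 3 `N#C/C(=C\c1ccccc1OS(=O)(=O)c1ccc(F)cc1)C(=O)Nc1nnc(Cc2cccc(F)c2)s1` has not yet been measured. Its structure differs from that of compound 2 through fluoro in place of nitro on an aromatic carbon with fluoro in place of nitro on an aromatic carbon, para to a large group. This reads further out as 4-nitrophenyl to 4-fluorophenyl. Among the measured compounds shown here, no measured step covers this change. In this assay compound 1, which also carries (4-fluorophenyl)sulfonyl, gives 6% as its value, and compound 2 is reported as "not toxic" (no number reported) without a figure. On that basis, no step beyond the scatter is expected in either direction. For compound 3 the expected value is 7% within an estimated range of 0% to 20% on this read-out.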

Compound 3, percent growth inhibition at one concentration: 17%
Compound 3: the middle estimate sits 10 percentage points below what was measured, and the stated range covers the measured number.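

In this assay, among these compounds, with (4-fluorophenyl)sulfonyl held fixed, 3-fluorophenyl in place of 4-methoxyphenyl on the saturated chain carbon bound to an aromatic carbon gives a number 11 percentage points higher from compound 1 to compound 3 (beyond the scatter), the first step that can be read. The change from 4-nitrophenyl to 4-fluorophenyl cannot be read as a step: compound 2 carries only a verbal "not toxic", while compound 3 gives 17%. Nothing on hand accounts for the higher number.

Open, as far as these compounds go, is how an amine in place of fluoro on that aromatic carbon, para to a large group, would read in this assay. Also open, from the compounds shown here alone, is whether the step holds at other concentrations, as each figure here comes from a single concentration.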